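The compounds below may be only part of what the source reports. "The series", "measured", "known", "first", "only" and "open" are said of these compounds alone.

Three analogues share the core of compound 1 `O=C(/C=C/c1ccc2c(c1)B(O)OC2)c1ccccc1`, which in a functional assay on SK-OV-3 cells (Homo sapiens) for cytotoxicity, read by MTT assay, with a stated time of 48 h (a lower number here means a stronger inhibitor, a higher number a weaker inhibitor), gives 3400 nM, the lowest of the three numbers, though both neighbours sit within the scatter of it: compound 2 `O=C(/C=C/c1ccc2c(c1)B(O)OC2)c1ccc(-c2ccccc2)cc1` gives 4900 nM and compound 3 `O=C(/C=C/c1ccc2c(c1)B(O)OC2)c1ccc(Cl)cc1` gives 3700 nM. The two measured steps from compound 1, a 1.4-fold higher number from compound 1 to compound 2 (0.16 log units; within the scatter) and a 1.1-fold higher number from compound 1 to compound 3 (0.04 log units; within the scatter), show that a substituent on that aromatic carbon barely moves the number. Compound 4 `CCc1ccc(C(=O)/C=C/c2ccc3c(c2)B(O)OC3)cc1` carries the change (ethyl in place of hydrogen on an aromatic carbon), the same kind of change, on an aromatic carbon, as the phenyl and chloro ones. Both earlier steps bear on it and both fell within the scatter, so no step beyond the scatter is expected in either direction. Compound 4 is therefore expected to give 3800 nM, with a range of 1900 nM to 7600 nM, a step of a 1.1-fold higher number from compound 1 to compound 4 (0.05 log units; within the scatter).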

Compound 4, half-maximal inhibitory concentration: 4400 nM
Compound 4: middle estimate off by 1.2-fold (0.06 log units), on the low side; the measured number falls inside the stated range.
By their numbers in this assay, from the lowest: compounds 1, 3, 4 and 2 (each within the scatter of the next).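

Ethyl, with no ring, joins phenyl and chloro on this aromatic carbon, para to a large group, without leaving the scatter: a 1.3-fold higher number from compound 1 to compound 4 (0.11 log units; within the scatter). The substituents also stay within the scatter of one another, with a 1.2-fold higher number from compound 3 to compound 4 (0.08 log units; within the scatter) and a 1.1-fold lower number from compound 2 to compound 4 (0.05 log units; within the scatter), so this series does not separate ethyl, chloro and phenyl at this position. Nothing available offers an explanation for this flat response.

Going by these compounds, whether an amine, a carboxylic acid or a longer chain on this carbon would move the number remains open. On these data alone, the effect of changes elsewhere on the core of compound 1 also remains open.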